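A Larger Amide Cap on the Acetamido Side Chain

This account rests on a few compounds, and the source may have more. Where it says the series, first, only, none or still open, it means among the compounds named here.

Compound 1 `C#CCNC1CCc2c(NCc3ccc(C)cc3)cccc21`, compound 2 `C#CCNC1CCc2c(SCc3ccc(Cl)cc3)cccc21` and compound 3 `C#CCNC1CCc2c(OCCc3cc(NC(C)=O)ccc3Cl)cccc21` share one core and differ only in the group attached to it. In an assay on cells for inhibition of Amine oxidase [flavin-containing] B (Homo sapiens), read by fluorescence and Amplex Red, with stated times of 30 min and 15 min (on this read-out higher numbers stand for weaker inhibition and lower numbers for stronger inhibition), compound 1 gives 250 nM, compound 2 gives 180 nM and compound 3 gives 590 nM. Of these three numbers compound 3 stands highest; its nearest neighbour is compound 1, at a gap that lies beyond the usual scatter, and its widest gap is to compound 2, also beyond the scatter. Compound 4 `C#CCNC1CCc2c(OCCc3cc(NC(=O)c4ccc(F)cc4)ccc3Cl)cccc21` has not yet been measured. It differs from compound 3 in one place: 4-fluorophenyl in place of methyl on a carbonyl carbon. Within the data shown here, no two measured compounds differ in a single place, so there is no measured step to lean on, and the expectation rests on the three values above and the change itself. Since compound 3 gives 590 nM and the change puts 4-fluorophenyl in place of methyl on the carbonyl carbon without altering the rest of the side chain, the step of a 1.5-fold lower number from compound 3 to compound 4 (0.17 log units; within the scatter) is expected to be modest, leaning toward a lower number, and not far outside the scatter. Compound 4 is therefore estimated at about 400 nM, within a range from 120 nM to 1300 nM.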

Compound 4, half-maximal inhibitory concentration: 5100 nM
Estimate against measurement, compound 4: 13-fold (1.11 log units) below; measured number outside the range, above it.
By their numbers in this assay, from the lowest: compounds 2 and 1 (each within the scatter of the next); then compound 3; then compound 4.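

The side chain of compound 3 proved sensitive at this point. In this assay, putting 4-fluorophenyl in place of methyl on the carbonyl carbon gives an 8.6-fold higher number from compound 3 to compound 4 (0.94 log units; beyond the scatter), a step well beyond the scatter and the only change in a single place among the compounds shown, so the earlier values could not have revealed it. It shows that the carbonyl carbon of the acetamido group is not a neutral place to extend from, since this exchange, which adds one six-membered aromatic ring and brings the substituent from 1 heavy atom to 7, costs a large part of the inhibition that compound 3 retains, and nothing measured alongside the result accounts for the loss.

The compounds shown leave open whether the loss goes with the ring, with the fluorine or simply with the added atoms; a plain phenyl, an ethyl or a cyclopropyl on the same carbonyl carbon would begin to separate these. They also leave open whether a methylene placed between the carbonyl and the 4-fluorophenyl ring, or a sulfonyl in place of the carbonyl, would recover the value of compound 3.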